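Removing a Methyl Group: Compound 1 to Compound 4

The source may report more compounds than this note shows. Statements on the series, on what has been measured and on what is new or still open speak of the compounds shown alone.

Compound 1 `Cc1ccc(C(=O)Oc2ccc(C)cc2C(=O)c2ccccc2)cc1` was tested in a functional assay on the whole organism (strain Albino) for inhibition, with Rattus norvegicus as the target, read by paw edema (on this read-out lower numbers stand for an effect already at smaller amounts and higher numbers for an effect only at larger amounts of compound), where compound 1 gives 75.5 mg/kg. This number is the second highest of the three measured. Compound 3 `Cc1ccc(C(=O)c2cc(F)ccc2OC(=O)c2ccc(Cl)cc2)cc1` gives 76.2 mg/kg and compound 2 `O=C(Oc1ccc(Cl)cc1C(=O)c1ccc(Cl)cc1)c1ccc(Cl)cc1` gives 65.5 mg/kg, and both lie within the scatter of compound 1. Compound 4 `Cc1ccc(OC(=O)c2ccccc2)c(C(=O)c2ccccc2)c1` has not yet been measured. It differs from compound 1 by hydrogen in place of methyl on an aromatic carbon. For the measured compounds named here, no measured pair shows this change. The three measured compounds, though they carry different substituents, sit within the scatter of one another. Compound 4 is therefore expected to show no step beyond the scatter in this assay. The expected step from compound 1 to compound 4 is a 1.0-fold lower number from compound 1 to compound 4 (0.00 log units; within the scatter). Compound 4 is estimated at 75 mg/kg, with a range from 45 mg/kg to 125 mg/kg.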

Compound 4, dose for half-maximal effect: 78.6 mg/kg
Beside the measured number, compound 4's estimate is 1.0-fold (0.02 log units) below it, and the stated range covers the measured number.
By their numbers in this assay, from the lowest: compounds 2, 1, 3 and 4 (each within the scatter of the next).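

Unlike the earlier compounds, this pair differs in one place only, so the change can be read on its own: in this assay going from 4-methylphenyl to phenyl gives a 1.0-fold higher number from compound 1 to compound 4 (0.02 log units; within the scatter) and stays within the scatter. The methyl group, para to a large group, can thus be lost from this position with no step beyond the scatter. Nothing on hand accounts for this result. The compounds shown leave open whether an amine, a carboxylic acid or a longer chain at this place would give a step beyond the scatter.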